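Sulfonamide aryl swap on the nitrogen: expectation for compound 3

The compounds below may be only part of what the source reports. "The series", "measured", "known", "first", "only" and "open" are said of these compounds alone.

Measured so far:
compound 1, `COc1ccc(Cl)cc1NS(=O)(=O)c1ccc(OC)c(N2CCNCC2)c1`: 1.26 nM
compound 2, `COc1ccc(S(=O)(=O)Nc2c(F)cc(Br)cc2F)cc1N1CCNCC1`: 158 nM

In an assay on isolated protein for binding affinity to 5-hydroxytryptamine receptor 6 (Homo sapiens) (a lower number here means a stronger inhibitor, a higher number a weaker inhibitor), compound 1 gives 1.26 nM and stands lowest of the two numbers; compound 2 gives 158 nM. For the measured compounds named here, the one measured step between them is a 130-fold higher number from compound 1 to compound 2 (2.10 log units; beyond the scatter), where the ring on the sulfonamide nitrogen is exchanged for a halogen-only ring.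

Compound 3, `COc1ccc(S(=O)(=O)Nc2cc(Cl)cc(Cl)c2Br)cc1N1CCNCC1`, has not yet been measured in this assay. It differs from compound 1 by 2-bromo-3,5-dichlorophenyl in place of 5-chloro-2-methoxyphenyl on a sulfonamide nitrogen. This is the same kind of exchange that the step from compound 1 to compound 2 describes: the 5-chloro-2-methoxyphenyl with its one hydrogen-bond acceptor leaves, and a ring carrying only halogens and no acceptor enters. Going by the values given here, only this one step bears on the change, so the direction is taken from it, and the size is expected to be of the same order, with wide uncertainty because the halogen pattern differs.

Compound 3 is therefore expected to give about 60 nM in this assay, within 8 nM to 400 nM. The expected step is a 48-fold higher number from compound 1 to compound 3 (1.68 log units; beyond the scatter), a clearly higher number.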

Compound 3, inhibition constant: 3.16 nM
The estimate for compound 3 lay 19-fold (1.28 log units) above the measured number, outside the stated range (below it).
By their numbers in this assay, from the lowest: compound 1; then compound 3; then compound 2.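

In this assay, the exchange at the sulfonamide nitrogen gives a 2.5-fold higher number from compound 1 to compound 3 (0.40 log units; beyond the scatter), so among the compounds shown, a low number at this position does not depend on the hydrogen-bond acceptor of the 5-chloro-2-methoxyphenyl group: the 2-bromo-3,5-dichlorophenyl group has none and still stays modestly apart from compound 1. The high number of compound 2 therefore cannot be read as a simple result of losing that acceptor, as the two rings carrying only halogens are themselves separated by a 50-fold lower number from compound 2 to compound 3 (1.70 log units; beyond the scatter), which places the large change in the halogen pattern. Nothing measured here explains why one halogen pattern is tolerated so much better than the other.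

Which halogens of the 2-bromo-3,5-dichlorophenyl group matter remains open: the step from compound 2 to compound 3 changes the whole pattern at once, so no single halogen can be credited with it. Also open, going by these compounds, is whether a ring carrying an amine or a carboxylic acid in place of these halogens would keep a number close to that of compound 1.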